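From a saturated ring to an aromatic ring on the amide

A few compounds are considered here, and "the series" means these few. Any claim that something is new, unique, unknown or untested is made for them only; others in the source may bear on it.

Compound 1 `O=C(NC1CCCCC1)c1ccccc1OCc1ccccc1` is a weak inhibitor: in an assay on lysate for inhibition of phosphatidylcholine:ceramide cholinephosphotransferase 2 (Homo sapiens), read by HPLC, with stated times of 30 min and 2 h (a lower number here means a stronger inhibitor, a higher number a weaker inhibitor), compound 1 gives 43400 nM. As far as these compounds go, compound 2 `O=C(NC1CCCNC1)c1ccccc1OCc1ccccc1Cl` gives only > 100000 nM in this assay, which is a limit of the assay and not a number, so compound 2 stands at the limit of > 100000 nM in this assay, at which 1 of the 2 values shown sits, and its true value is unknown. Compound 3 `O=C(Nc1cccnc1)c1ccccc1OCc1ccccc1Cl` differs from compound 2 in one place: pyridin-3-yl in place of piperidin-3-yl on an amide-type nitrogen. Within the data shown here, no measured pair shows this change, so the step from compound 2 to compound 3 is expected to be an at least 1.6-fold lower number from compound 2 to compound 3 (0.22 log units; that floor lies within the scatter), modest and with uncertain direction. Compound 3 is therefore estimated at 60000 nM, within a range from 15000 nM to 200000 nM.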

Compound 3, half-maximal inhibitory concentration: 1100 nM
Compound 3: the middle estimate sits 55-fold (1.74 log units) above what was measured; the measured number lies below the stated range.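

Putting pyridin-3-yl in place of piperidin-3-yl on the amide-type nitrogen gives an at least 90-fold lower number from compound 2 to compound 3 (1.95 log units; beyond the scatter) in this assay. This position therefore responds strongly to the ring it carries, even though both rings are six-membered and hold one hetero atom. The step can be read only as a floor, and its full size stays unknown: the limit of > 100000 nM in this assay, at which 1 of the 3 values shown sits.

As far as these compounds go, what a plain phenyl ring or a pyridin-4-yl ring would give on this nitrogen remains open. So does the question of whether the ring nitrogen of compound 3 is needed at all.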